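Vinyl to Cyano on a Fused Core: Hepatic Extraction Outlook

The compounds below may be only part of what the source reports. "The series", "measured", "known", "first", "only" and "open" are said of these compounds alone.

Measured compounds:
- Compound 1, `CCC(CC)n1c(=O)[nH]c2nccnc21`: "not determined" (no result reported)
- Compound 2, `CCC(CC)n1c(=O)[nH]c2ncc(Cl)nc21`: < 0.2 (a limit of the assay)
- Compound 3, `C=Cc1cnc2[nH]c(=O)n(C(CC)CC)c2n1`: 0.5

For the measured compounds named here, in an ADME assay on microsomes from liver (Homo sapiens), read by LC-MS, with a stated time of 90 min (on this read-out lower numbers stand for lower hepatic extraction and higher numbers for higher hepatic extraction), compound 3 gives 0.5, the only single number among the three compounds. Compound 2 is reported only as a limit, < 0.2, which is the limit of < 0.2 in this assay, at which 1 of the 3 values shown sits. Compound 1 is reported as "not determined" (no result reported).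

Going by the values given here, the one measured step, vinyl in place of chloro on an aromatic carbon, is a number at least 0.30 higher from compound 2 to compound 3 (beyond the scatter). The next compound is compound 4, `CCC(CC)n1c(=O)[nH]c2ncc(C#N)nc21`, which differs from compound 3 as follows: cyano in place of vinyl on an aromatic carbon

The step from compound 2 to compound 3 bears on compound 4 only loosely: it shows that swapping the group at this aromatic carbon can move hepatic extraction by at least a modest amount, but it compares chloro with vinyl, not vinyl with cyano. With a single relevant step and a limit as one of its ends, the direction for cyano is uncertain. Compound 4 is expected to give about 0.3 in this assay, with a range of 0.15 to 0.5. That corresponds to an estimated step of a number 0.20 lower from compound 3 to compound 4 (beyond the scatter), with a real chance that the assay again reports only a limit.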

Compound 4, hepatic extraction ratio: < 0.2
Compound 4: only a limit was reported (the forecaster's own chance of this, stated with the estimate: 30%); middle value at least 0.10 from the limit.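

In this assay, putting cyano in place of vinyl gives a number at least 0.30 lower from compound 3 to compound 4 (beyond the scatter). This shows that the earlier rise from chloro to vinyl is not a one-way trend at this aromatic carbon: a group of the same heavy-atom count can bring the read-out back down, so the reading depends on which group sits here, not merely on the replacement of chloro. The step between compound 2 and compound 4 cannot be read, and chloro and cyano cannot be ranked against each other, because both compounds are reported only at the same limit of the assay, not as numbers: the limit of < 0.2 in this assay, at which 2 of the 4 values shown sit.

From the compounds shown here alone, compound 1, with only hydrogen on this carbon, gives "not determined" (no result reported), so the reading of the unsubstituted core remains open, and with it whether vinyl raises the read-out or chloro and cyano lower it. Going by these compounds, it also remains open whether the high reading is particular to vinyl or would return with another group at this carbon, such as an ethyl chain, a methoxy group or an amine.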